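Urea analogues on the shared core: phenol in place of methoxy

The source may hold more compounds than are shown below. What is called first, only, known or untested is meant among the compounds shown, and "the series" means these compounds.

Measured so far in a functional assay on RPMI-8226 cells (Homo sapiens) for inhibition, read by sulforhodamine B assay, with a stated time of 48 h; a higher number here means a weaker inhibitor of growth, a lower number a stronger inhibitor of growth:
Compound 1 `COc1cc(-c2nn(-c3cccc(NC(=O)c4ccc(Cl)c(C(F)(F)F)c4)c3)cc2-c2ccncc2)ccc1Cl` — in this assay compound 1 gives only a limit, > 32500 nM.
Compound 2 `COc1cc(-c2nn(-c3cccc(NC(=O)c4cccc(C(F)(F)F)c4)c3)cc2-c2ccncc2)ccc1Cl` — compound 2 gives 26600 nM.
Compound 3 `COc1cc(-c2nn(-c3cccc(NC(=O)Nc4ccc(Cl)c(C(F)(F)F)c4)c3)cc2-c2ccncc2)ccc1Cl` — compound 3 gives 3250 nM.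

Compound 3 holds the lowest of the two real numbers; the nearest is compound 2, with an 8.2-fold lower number from compound 2 to compound 3 (0.91 log units; beyond the scatter), and the step of an at least 10-fold lower number from compound 1 to compound 3 (1.00 log units; beyond the scatter) runs from a limit, as shown by the limit of > 32500 nM in this assay, at which 1 of the 3 values shown sits. The step of an at least 1.2-fold lower number from compound 1 to compound 2 (0.08 log units; that floor lies within the scatter) lies within the scatter. All three measured steps concern the group on the carbonyl carbon.

Compound 4 `O=C(Nc1cccc(-n2cc(-c3ccncc3)c(-c3ccc(Cl)c(O)c3)n2)c1)Nc1ccc(Cl)c(C(F)(F)F)c1` differs from compound 3 only at the ring bearing the methoxy group: hydrogen in place of methyl on an oxygen on an aromatic ring. Going by the values given here, no measured step touches that oxygen, so none of the three bears directly on this change, and no step beyond the scatter in this assay is expected from it. Compound 4 is therefore estimated at 3500 nM, with a range of 1200 nM to 10000 nM. This estimate means a 1.1-fold higher number from compound 3 to compound 4 (0.03 log units; within the scatter), which is expected to sit within the scatter.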

Compound 4, concentration for total growth inhibition: 2000 nM
For compound 4 the middle estimate is 1.8-fold (0.24 log units) above the measured one; low and high end bracket the measured number.
By their numbers in this assay, from the lowest: compounds 4 and 3 (each within the scatter of the next); then compound 2. At a limit, above all of these: compound 1.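

In this assay, the only step shown that touches the oxygen on the aromatic ring, methoxy to hydroxy, gives a 1.6-fold lower number from compound 3 to compound 4 (0.21 log units; within the scatter). On this urea, then, the methyl on that oxygen can be lost without a change that can be told from the scatter, so the 4-chloro-3-hydroxyphenyl and 4-chloro-3-methoxyphenyl forms read as equivalent at this position. Nothing in the data shown accounts for this step or bears on it.

From the compounds shown here alone, how much this oxygen position accepts remains open: a longer chain such as ethoxy or propoxy, or an amine in place of the hydroxy, would test whether the flat result extends beyond these two groups. Also open, going by these compounds, is whether methoxy to hydroxy behaves the same way on the amide analogues, compound 1 and compound 2, since the step is read on a single urea pair.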